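The source may hold more compounds than are shown below. What is called first, only, known or untested is meant among the compounds shown, and "the series" means these compounds.

In a functional assay on brain (Rattus norvegicus, strain Wistar) for inhibition; on this read-out lower numbers stand for stronger inhibition and higher numbers for weaker inhibition:
- compound 1 `CCCCc1ccc(-c2c(C)[nH]c(=O)n2C)cc1` gives 10700 nM
- compound 2 `CCCCCCOc1ccc(-c2c(C)[nH]c(=O)n2C)cc1` gives 7300 nM

For the measured compounds named here, compound 2 cannot be separated from compound 1, the only other measured compound. Compound 3 `Cc1[nH]c(=O)n(C)c1-c1ccc(Oc2ccccc2)cc1` follows from compound 2 by phenyl in place of hexyl on an oxygen on an aromatic ring. Going by the values given here, the only measured step, a 1.5-fold lower number from compound 1 to compound 2 (0.17 log units; within the scatter), stays within the scatter. Among the compounds with values here, it exchanges butyl for hexyloxy, so it bears only loosely, and no measured step puts a ring on that oxygen. No step beyond the scatter is therefore expected in this assay, and no direction is favoured. Compound 3 is estimated at 7000 nM, within a range of 2000 nM to 25000 nM as the expected span. The estimate means an expected step of a 1.0-fold lower number from compound 2 to compound 3 (0.02 log units; within the scatter) in this read-out.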

Compound 3, half-maximal inhibitory concentration: 8100 nM
The estimate for compound 3 lay 1.2-fold (0.06 log units) below the measured number; the range from low to high includes it.
By their numbers in this assay, from the lowest: compounds 2, 3 and 1 (each within the scatter of the next).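

In this assay a ring on the oxygen now has a reading: a 1.1-fold higher number from compound 2 to compound 3 (0.05 log units; within the scatter) stays within the scatter, so hexyloxy and phenoxy are not separated at this position. Against butyl, a 1.3-fold lower number from compound 1 to compound 3 (0.12 log units; within the scatter) is also within the scatter, which leaves butyl, hexyloxy and phenoxy all reading alike here. No supporting data on hand accounts for this result. Open, on these data alone, is whether any group at this position moves the number beyond the scatter, such as an amine or a carboxylic acid in place of phenoxy. Also open, as far as these compounds go, is whether changes on the shared core do so.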